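A few compounds are considered here, and "the series" means these few. Any claim that something is new, unique, unknown or untested is made for them only; others in the source may bear on it.

Measured so far in a functional assay on the whole organism (strain Kunming) with Mus musculus as the target, with a stated time of 0.5 h, at a dose of 100 mg/kg by the intraperitoneal route; on this read-out lower numbers stand for a stronger effect and higher numbers for a weaker effect at the one dose given:
compound 1 `COc1cc(OC)c(OC)cc1/C=C/COC(=O)/C=C/c1ccc(Br)cc1` gives 100%
compound 2 `COc1cc(OC)c(OC)cc1/C=C/COC(=O)/C=C/c1cccc(Br)c1` gives 100%
compound 3 `COc1cc(OC)c(OC)cc1/C=C/COC(=O)/C=C/c1ccccc1Cl` gives 100%

Compound 3 stands level with compounds 1 and 2 on these numbers; its nearest neighbour is compound 1 and its furthest is compound 2, and in both cases the gap lies within the scatter of repeated measurements, so none of the three can be called stronger or weaker than another. All three share one core and differ only in the aromatic ring that sits on a double-bonded chain carbon bound to a double-bonded chain carbon.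

Compound 4 `COc1cc(OC)c(OC)cc1/C=C/COC(=O)/C=C/c1ccc(F)cc1` has not yet been measured. It differs from compound 3 in one place: 4-fluorophenyl in place of 2-chlorophenyl on a double-bonded chain carbon bound to a double-bonded chain carbon. For the measured compounds named here, three measured steps bear on this kind of exchange, each replacing one such ring by another at the same place: no change at the digits printed from compound 1 to compound 2 (within the scatter), no change at the digits printed from compound 1 to compound 3 (within the scatter) and no change at the digits printed from compound 2 to compound 3 (within the scatter). None of them moved the read-out beyond the scatter. On that basis, the step to compound 4 is expected to bring no change beyond the scatter either, no change at the digits printed from compound 3 to compound 4 (within the scatter). Compound 4 is therefore estimated to give 100%, with a range from 90% to 100%.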

Compound 4, a percentage reported as activity, at one dose (the size of the read-out at that dose, not a potency): 100%
For compound 4 middle estimate and measured number coincide at the digits printed; measured number inside the range.
By their numbers in this assay, from the lowest: compounds 1, 2, 3 and 4 (each within the scatter of the next).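

In this assay, the ring on a double-bonded chain carbon bound to a double-bonded chain carbon now accepts fluoro as well as bromo and chloro, with 4-fluorophenyl matching both 2-chlorophenyl (no change at the digits printed from compound 3 to compound 4 (within the scatter)) and 3-bromophenyl (no change at the digits printed from compound 2 to compound 4 (within the scatter)). For the compounds shown here, the most direct comparison is fluoro in place of bromo on an aromatic carbon, with the halogen's place on the ring unchanged (no change at the digits printed from compound 1 to compound 4 (within the scatter)), so at this dose the read-out does not distinguish these two halogens, a contrast that the earlier compounds did not test at a single ring place. Nothing measured here explains why the read-out stays the same across these rings.

From the compounds shown here alone, all four compounds carry a halogen on this ring, so it remains open whether an unsubstituted phenyl, or a ring bearing an amine or a carboxylic acid, would move the read-out beyond the scatter. Going by these compounds, with a single dose and a single time point, it also remains open whether these four halogenated compounds would still match one another at other doses.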